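A few compounds are considered here, and "the series" means these few. Any claim that something is new, unique, unknown or untested is made for them only; others in the source may bear on it.

Series notes. Compound 1 `CCOC(=O)C1=CCCCC1S(=O)(=O)Nc1ccccc1F` and compound 2 `CCOC(=O)C1=CCCCC1S(=O)(=O)Nc1cccc(F)c1F` share one core; compound 3 `CCOC(=O)C1=C(S(=O)(=O)Nc2ccccc2)CCCC1` and compound 4 `CCOC(=O)C1=C(S(=O)(=O)Nc2ccc(F)cc2)CCCC1` share another, and the difference between the two cores is not broken down here. In a functional assay on RAW264.7 cells (Mus musculus) for inhibition (on this read-out lower numbers stand for stronger inhibition and higher numbers for weaker inhibition), compound 1 gives 75 nM. In this assay compound 2 gives 140 nM. The change fluoro in place of hydrogen on an aromatic carbon makes a step of a 1.9-fold higher number from compound 1 to compound 2 (0.27 log units; within the scatter). Within the data shown here, for compound 3, this assay reports only a limit, > 8200 nM, which is the one value sitting at the limit of > 8200 nM in this assay, at which 1 of the 3 values shown sits. The change fluoro in place of hydrogen on an aromatic carbon is the same kind of change, though the place differs: in compound 2 the fluoro sits ortho to a fluoro group and meta to a large group, in compound 4 para to a large group. Given the measured step of a 1.9-fold higher number from compound 1 to compound 2 (0.27 log units; within the scatter) sits within the scatter, a step that the limit leaves unreadable from compound 3 to compound 4 is expected, with a limit again likely. Compound 4 is estimated at 12000 nM, from 4000 nM to 40000 nM.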

Compound 4, half-maximal inhibitory concentration: 1400 nM
For compound 4 the middle estimate is 8.6-fold (0.93 log units) above the measured one, outside the stated range (below it).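

In this assay, fluoro in place of hydrogen on an aromatic carbon gives an at least 5.8-fold lower number from compound 3 to compound 4 (0.76 log units; beyond the scatter), and the change does not carry over from one core to the other with the same size or direction: the same change on two cores in this assay, a 1.9-fold higher number (0.27 log units; within the scatter) from compound 1 to compound 2 and an at least 5.8-fold lower number (0.76 log units; beyond the scatter) from compound 3 to compound 4, at least 10-fold (1.03 log units) apart, beyond the scatter of two such steps

On these data alone, compound 3 stands at a limit, > 8200 nM, so the new step is a bound and its true size stays open. The two steps also differ in where the fluoro sits, so the effect of the core cannot be told apart from that of the place.

As far as these compounds go, it remains open whether a fluoro para to a large group would give a similar step on the core of compound 1. From the compounds shown here alone, it is also open whether a chloro, a methoxy or an amine in that place on the core of compound 4 would follow the fluoro.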